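Oxazolyl for methyl: expected cytotoxicity of compound 4

The source may hold more compounds than are shown below. What is called first, only, known or untested is meant among the compounds shown, and "the series" means these compounds.

Measured so far in an ADME assay on PC-3 cells (Homo sapiens) for cytotoxicity, read by WST assay, tested at 100 uM; on this read-out lower numbers stand for less inhibition and higher numbers for more inhibition at the one concentration tested (going by the name of the read-out):
compound 1 `O=C(Nc1cccc(Oc2nccc(C(F)(F)F)c2Cl)c1)C1CCCN(C(=O)c2cc(C(F)(F)F)cc(C(F)(F)F)c2)C1` gives 0%
compound 2 `COC(=O)c1cccc(NC(=O)C2CCCN(C(=O)c3cc(C(F)(F)F)cc(C(F)(F)F)c3)C2)c1` gives 0%
compound 3 `Cc1cccc(C(=O)N2CCCC(C(=O)Nc3ccc(Cl)cc3)C2)c1` gives 0%

Compound 3 stands level with compounds 1 and 2 in this assay; the three values lie within the scatter of one another. Among the compounds with values here, the single measured step, no change at the digits printed from compound 1 to compound 2 (within the scatter), altered the read-out by nothing beyond the scatter, and it is the only step that speaks to the question at all. Compound 4 `O=C(Nc1ccc(Cl)cc1)C1CCCN(C(=O)c2cccc(-c3cnco3)c2)C1` differs from compound 3 by 1,3-oxazol-5-yl in place of methyl on an aromatic carbon. Within the data shown here, no measured pair exchanges a methyl for an oxazolyl group, so the guide is simply that every change seen so far left the read-out flat. A step of no change at the digits printed from compound 3 to compound 4 (within the scatter) is therefore expected, none beyond the scatter. Compound 4 is estimated to give 0%, within a range from 0% to 12%.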

Compound 4, a percentage reported as inhibition, at one concentration (the size of the read-out at that concentration, not a potency): 0%
Compound 4: middle estimate and measured number agree at the digits printed; low and high end bracket the measured number.
By their numbers in this assay, from the lowest: compounds 1, 2, 3 and 4 (each within the scatter of the next).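

In this assay, 1,3-oxazol-5-yl in place of methyl on an aromatic carbon, meta to a large group, gives no change at the digits printed from compound 3 to compound 4 (within the scatter) and is the first step shown at this position. A group of 5 heavy atoms with one five-membered aromatic ring and 2 hydrogen-bond acceptors, replacing a single carbon, therefore leaves this read-out flat. Nothing available explains this flat result.

Going by these compounds, whether an amine or a carboxylic acid at this position would move the read-out remains open. So does whether any change to the shared core would.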